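Ethoxycarbonyl to isopropoxycarbonyl: the step from compound 2

The source may hold more compounds than are shown below. What is called first, only, known or untested is meant among the compounds shown, and "the series" means these compounds.

Of the compounds shown here, three have numbers so far. In an ADME assay on a cell-free system (plasma, Homo sapiens) for metabolic stability, read by LC-MS, with a stated time of 60 min, tested at 10 uM (on this read-out lower numbers stand for a less stable compound and higher numbers for a more stable compound), compound 2 (`CCOC(=O)[C@H](CCC(=O)C=[N+]=[N-])NC(=O)OCc1oc(=O)oc1C`) gives 0% and lies within the scatter of compound 3 (`CC(C)C[C@H](N)C(=O)N[C@@H](CCC(=O)C=[N+]=[N-])C(=O)OC(C)C`), which gives 1% on the same read-out. Compound 1 (`CCC(OC(=O)N[C@@H](CCC(=O)C=[N+]=[N-])C(=O)OC)OC(=O)C(C)(C)C`) gives 88% and stands beyond the scatter from both.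

The unmeasured compound 4 (`Cc1oc(=O)oc1COC(=O)N[C@@H](CCC(=O)C=[N+]=[N-])C(=O)OC(C)C`) differs from compound 2 in one place: methyl in place of hydrogen on a saturated chain carbon bound to an oxygen next to a carbonyl group and a saturated chain carbon on a saturated chain carbon bound to an oxygen next to a carbonyl group. The same difference reads ethoxycarbonyl to isopropoxycarbonyl.

Within the data shown here, no measured step sizes this change directly. Compound 3 carries the isopropoxycarbonyl group as well and gives 1% in this assay, so a large rise is not expected. The expected a number 5 percentage points higher from compound 2 to compound 4 (within the scatter) is small, upward if anything, and within the scatter. Compound 4 is estimated at 5% with 0% to 25% as the expected range.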

Compound 4, percent of the compound remaining: 0%
Estimate against measurement, compound 4: 5 percentage points above, and the stated range covers the measured number.
By their numbers in this assay, from the lowest: compounds 2, 4 and 3 (each within the scatter of the next); then compound 1.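

In this assay, the series now has its first measured step that differs in one place: ethoxycarbonyl to isopropoxycarbonyl gives no change at the digits printed from compound 2 to compound 4 (within the scatter) and leaves both compounds at the bottom of the read-out. Methyl in place of hydrogen on this saturated chain carbon therefore does not lift a compound of this type out of that low range, although a step starting so low cannot show whether the change would matter on a more stable compound. No available evidence bears on the reason for this result.

From the compounds shown here alone, whether a tert-butyl group or a longer chain at this ester position would give a different number remains open. Also open, going by these compounds, is whether the same change would move a number on the core of compound 1, which gives 88% in this same read-out.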